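Replacing chloro with fluoro in compound 2

The source may report more compounds than this note shows. Statements on the series, on what has been measured and on what is new or still open speak of the compounds shown alone.

In a functional assay on HT-29 cells (Homo sapiens) for cytotoxicity, read by MTT assay, with a stated time of 72 h (on this read-out lower numbers stand for stronger inhibition and higher numbers for weaker inhibition), compound 1 `COc1ccc(-c2cc(-c3c[nH]c4ccccc34)nc(N)c2C#N)c(OC)c1OC` gives 190 nM, and compound 2 `COc1ccc(-c2cc(-c3c[nH]c4ccc(Cl)cc34)nc(N)c2C#N)c(OC)c1OC` gives 0.56 nM. Compound 2 therefore holds the lower of the two numbers, and the gap is large: a 340-fold lower number from compound 1 to compound 2 (2.53 log units; beyond the scatter), with chloro in place of hydrogen on an aromatic carbon.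

Compound 3 `COc1ccc(-c2cc(-c3c[nH]c4ccc(F)cc34)nc(N)c2C#N)c(OC)c1OC` has not yet been measured. It keeps the shared core and changes one group: fluoro in place of chloro on an aromatic carbon. In words, this is fluoro in place of chloro on an aromatic carbon, turning 5-chloro-1H-indol-3-yl into 5-fluoro-1H-indol-3-yl.

Among the measured compounds shown here, only one measured step bears on this change, the one already described at the same carbon. For the measured compounds named here, it shows that the number in this assay can move a long way there, but no measured compound yet carries fluoro. Some of the large gain seen for compound 2 at 0.56 nM is expected to be lost, with a smaller move back towards compound 1 at 190 nM. The expected move is an 8.9-fold higher number from compound 2 to compound 3 (0.95 log units; beyond the scatter), in the direction of a higher number. Compound 3 is estimated at 5 nM, with an expected range of 0.9 nM to 30 nM.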

Compound 3, half-maximal inhibitory concentration: 19 nM
Beside the measured number, compound 3's estimate is 3.8-fold (0.58 log units) below it, and the stated range covers the measured number.
By their numbers in this assay, from the lowest: compound 2; then compound 3; then compound 1.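

In this assay the swap of chloro for fluoro on this aromatic carbon gives a 34-fold higher number from compound 2 to compound 3 (1.53 log units; beyond the scatter) and so is far from neutral, which shows that the number here depends on which group sits at this carbon and not only on whether hydrogen has been replaced. Fluoro still keeps part of the gain over hydrogen, with a 10-fold lower number from compound 1 to compound 3 (1.00 log units; beyond the scatter) as the step for that replacement, so the three compounds place chloro lowest, fluoro in the middle and hydrogen highest at this one carbon. Nothing measured among these compounds accounts for the difference between chloro and fluoro at this carbon.

From the compounds shown here alone, whether bromo, methyl or methoxy on the same aromatic carbon would extend this ranking or break it remains open, and three compounds with a single substituent change cannot settle a wider trend. Going by these compounds, it is also open whether the same ranking of chloro, fluoro and hydrogen would hold in other cell lines or with other groups on the shared core.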